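A few compounds are considered here, and "the series" means these few. Any claim that something is new, unique, unknown or untested is made for them only; others in the source may bear on it.

Two amines on a shared core have been tested in a functional assay on PC-3 cells (Homo sapiens) for antiproliferative activity, read by MTT assay, with a stated time of 72 h; on this read-out higher numbers stand for weaker inhibition and lower numbers for stronger inhibition. Compound 1, `CCCCCCCNC[C@@H]1OC[C@H](N)[C@H]1O`, gives > 128000 nM, which is a limit of the assay and not a number. Among the measured compounds shown here, compound 2, `CCCCCCCCNC[C@@H]1OC[C@H](N)[C@H]1O`, gives 13000 nM, the only true number so far, so its standing rests on that one comparison. Compound 3, `CCCCCCCCCCNC[C@@H]1OC[C@H](N)[C@H]1O`, has ethyl in place of hydrogen on a saturated chain carbon, eight bonds along the chain from an amine nitrogen, as ethyl in place of hydrogen on a saturated chain carbon, eight bonds along the chain from an amine nitrogen sets out. For the measured compounds named here, one measured step bears on this change: an at least 9.8-fold lower number from compound 1 to compound 2 (0.99 log units; beyond the scatter), which came from methyl in place of hydrogen on a saturated chain carbon, seven bonds along the chain from an amine nitrogen. The true size of that step is open, since it starts from a limit, and a single step sets no trend. Going by that step in this assay, a further fall of similar or smaller size is expected. The expected change is a 3.7-fold lower number from compound 2 to compound 3 (0.57 log units; beyond the scatter). The estimate for compound 3 is 3500 nM, with an expected range from 1000 nM to 11000 nM.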

Compound 3, half-maximal inhibitory concentration: > 128000 nM
Compound 3 ended at the assay's limit; the forecaster's own chance of this, stated with the estimate: 3%; middle value at least 36-fold (1.56 log units) from the limit.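

In this assay, extending the chain does not keep lowering the number: ethyl in place of hydrogen on a saturated chain carbon, eight bonds along the chain from an amine nitrogen, gives an at least 9.8-fold higher number from compound 2 to compound 3 (0.99 log units; beyond the scatter), which runs against the earlier at least 9.8-fold lower number from compound 1 to compound 2 (0.99 log units; beyond the scatter). From the compounds shown here alone, compound 3 gives > 128000 nM, which is a limit of the assay and not a number, so the true size of this rise stays open. Among the three compounds, the chain at this position therefore does not behave as a steady trend, since only compound 2 gives a true number, while the step between the other two cannot be read and both sit at the same limit: the limit of > 128000 nM in this assay, at which 2 of the 3 values shown sit.

The compounds shown leave open how sharply the number changes around compound 2, which a nonyl chain on the same shared core could help to settle. They also leave open whether a still longer chain stays at the limit, and whether a hydroxyl or an amine at the far end of the chain would alter the outcome.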